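A New Phenyl Group on the Carbonyl Carbon

The compounds below may be only part of what the source reports. "The series", "measured", "known", "first", "only" and "open" are said of these compounds alone.

In an ADME assay on MT4 cells (Homo sapiens) for cytotoxicity, read by MTT assay (on this read-out lower numbers stand for higher toxicity in this test and higher numbers for lower toxicity in this test), compound 1 (`Cc1ccc(N(C(=O)c2cc(F)ccc2F)C(=S)OCCN2C(=O)c3ccccc3C2=O)cc1`) reads 62000 nM and compound 2 (`Cc1ccc(N(C(=O)c2ccc(Cl)cc2Cl)C(=S)OCCN2C(=O)c3ccccc3C2=O)cc1`) reads 49000 nM while compound 3 (`COc1cccc(OC)c1C(=O)N(C(=S)OCCN1C(=O)c2ccccc2C1=O)c1ccc(C)cc1`) reads 36000 nM with all three inside the usual scatter of one another. Compound 4 (`Cc1ccc(N(C(=O)c2ccc(Br)c(C)c2)C(=S)OCCN2C(=O)c3ccccc3C2=O)cc1`) differs from compound 3 only in the group on the carbonyl carbon (4-bromo-3-methylphenyl in place of 2,6-dimethoxyphenyl on a carbonyl carbon) with 4-bromo-3-methylphenyl in place of 2,6-dimethoxyphenyl. Three measured swaps at that place bear on this. They are a 1.3-fold lower number from compound 1 to compound 2 (0.10 log units; within the scatter) and a 1.7-fold lower number from compound 1 to compound 3 (0.24 log units; within the scatter) and a 1.4-fold lower number from compound 2 to compound 3 (0.13 log units; within the scatter) and each stays within the scatter. Within the data shown here, no measured compound carries bromine. No step beyond the scatter is expected in this assay in either direction. The estimated step is a 1.1-fold higher number from compound 3 to compound 4 (0.05 log units; within the scatter) and stays small. For compound 4 the expected value is 40000 nM within an estimated range (15000 nM to 100000 nM).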

Compound 4, half-maximal cytotoxic concentration: > 100000 nM
Compound 4: no number, only a limit; the forecaster's own chance of this, stated with the estimate: 15%; at least 2.5-fold (0.39 log units) between middle value and limit.
By their numbers in this assay, from the lowest: compounds 3, 2 and 1 (each within the scatter of the next). At a limit, above all of these: compound 4.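

Compound 4 gives a limit in this assay, not a number: the limit of > 100000 nM in this assay, at which 1 of the 4 values shown sits.

Among these compounds, earlier swaps of the group on this carbonyl carbon all stayed within the scatter, whereas this change gives the first step beyond it, with an at least 2.7-fold higher number from compound 3 to compound 4 (0.44 log units; beyond the scatter). Against the other two compounds, only a floor within the scatter can be read, with an at least 2.0-fold higher number from compound 2 to compound 4 (0.30 log units; that floor lies within the scatter) and with an at least 1.6-fold higher number from compound 1 to compound 4 (0.20 log units; that floor lies within the scatter).

The compounds shown leave open whether the bromine or the methyl goes with this step. Also open, on these data alone, is how a phenyl group carrying an amine or a carboxylic acid would read at this place.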